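Adding a Dimethylaminophenyl Arm to an Ester Benzamide

The source may report more compounds than this note shows. Statements on the series, on what has been measured and on what is new or still open speak of the compounds shown alone.

Compound 2 `CCOC(=O)CCCCCOc1cccc(CN(C(=O)c2ccccc2)C(C)C)c1` joins a plain benzamide to an ethyl ester on a six-carbon chain. In an ADME assay on HepG2 cells (Homo sapiens) for cytotoxicity, read by CellTiter-Glo and resazurin assay, with a stated time of 72 h (a higher number here means that more compound is needed for the effect, a lower number that less compound is needed), compound 2 reaches only a limit, giving > 26000 nM. Compound 1 `CC(C)N(Cc1cccc(OCCCCCC(=O)O)c1)C(=O)c1ccc(-c2cccc(N(C)C)c2)cc1`, which instead pairs the dimethylaminophenyl-bearing benzamide with a free acid chain, likewise shows only a limit, giving > 26000 nM in this assay. For the measured compounds named here, both values sit at the limit of > 26000 nM in this assay, at which 2 of the 2 values shown sit, so no measured step between compounds differing in one place can be drawn from them. Compound 3 `CCOC(=O)CCCCCOc1cccc(CN(C(=O)c2ccc(-c3cccc(N(C)C)c3)cc2)C(C)C)c1` combines features of both: it differs from compound 2 by 3-(dimethylamino)phenyl in place of hydrogen on an aromatic carbon. Since the two measured values both rest at the limit of > 26000 nM in this assay, at which 2 of the 2 values shown sit, the expected step is a step that the limit leaves unreadable from compound 2 to compound 3, none beyond the scatter. Compound 3 is therefore estimated at 30000 nM, most likely again only a limit, with a range from 10000 nM to 100000 nM.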

Compound 3, half-maximal effective concentration: > 26000 nM
Compound 3 gave a limit, no number (the forecaster's own chance of this, stated with the estimate: 85%); the middle value is on the limit's open side.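

No step can be read from compound 2 to compound 3 or from compound 1 to compound 3, because all three compounds rest at the same limit: (the limit of > 26000 nM in this assay, at which 3 of the 3 values shown sit). The compounds shown leave open how much the 3-(dimethylamino)phenyl group or the ethyl group changes the concentration needed for the effect.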